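Swapping Cyclopropyl for Isopropyl on a Sulfonamide Nitrogen

A few compounds are considered here, and "the series" means these few. Any claim that something is new, unique, unknown or untested is made for them only; others in the source may bear on it.

compound 1 `O=C(NO)c1ccc2c(c1)CCN(S(=O)(=O)c1cc(F)c(F)c(F)c1F)C2` — > 1000 nM
compound 2 `O=C(NO)c1ccc(CN(C2CC2)S(=O)(=O)c2cc(F)c(F)c(F)c2F)cc1` — > 1000 nM
compound 3 `CC(C)N(Cc1ccc(C(=O)NO)cc1)Cc1cc(F)c(F)c(F)c1F` — > 1000 nM

All three compounds were tested in an assay on Sf9 cells for inhibition of histone deacetylase 8 (Homo sapiens), read by fluorescence and mobility shift assay; a lower number here means a stronger inhibitor, a higher number a weaker inhibitor. Compound 1 reaches only the limit of > 1000 nM, which is a boundary of the measurement and not a number. Compound 2 likewise sits at the limit of > 1000 nM. Compound 3 also stops at the limit of > 1000 nM. So compound 2 stands nowhere in particular among the numbers shown: every value is the limit of > 1000 nM in this assay, at which 3 of the 3 values shown sit, and no compound can be ranked against another.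

Compound 4 `CC(C)N(Cc1ccc(C(=O)NO)cc1)S(=O)(=O)c1cc(F)c(F)c(F)c1F` is built from compound 2 by a single change: isopropyl in place of cyclopropyl on a sulfonamide nitrogen. Going by the values given here, no pair of measured compounds shows what such a change does, so there is no step to lean on. Because compound 2 gives > 1000 nM, the expectation is that the change from compound 2 to compound 4 brings no movement beyond the scatter, estimated as a step that the limit leaves unreadable from compound 2 to compound 4. Compound 4 is therefore expected to give about 3000 nM in this assay, within a range from 1000 nM to 10000 nM, most likely again as a limit rather than a number.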

Compound 4, half-maximal inhibitory concentration: > 1000 nM
Compound 4: no number, only a limit; the forecaster's own chance of this, stated with the estimate: 75%; the middle value is on the limit's open side.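

No step can be read from compound 2 to compound 4, because each gives only a limit of the assay and not a number: the limit of > 1000 nM in this assay, at which 4 of the 4 values shown sit.

Whether isopropyl and cyclopropyl on a sulfonamide nitrogen differ at all in this assay stays open, as does how strongly any of these compounds inhibits.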